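Para-substituent swap on the aryl ring of the shared core

The compounds below may be only part of what the source reports. "The series", "measured", "known", "first", "only" and "open" are said of these compounds alone.

Compound 3 `COc1ccc(-n2c(=O)c(C(=O)Nc3ccc(Oc4ncnc5c4ccn5C)cc3)cc3cccnc32)cc1` shares its core with compound 1 `Cn1ccc2c(Oc3ccc(NC(=O)c4cc5cccnc5n(-c5ccccc5)c4=O)cc3)ncnc21` and compound 2 `Cn1ccc2c(Oc3ccc(NC(=O)c4cc5cccnc5n(-c5ccc(Cl)cc5)c4=O)cc3)ncnc21`, the three differing only in the substituent on the pendant phenyl ring. In a functional assay on HeLa cells (Homo sapiens) for cytotoxicity, read by MTT assay, with a stated time of 72 h (on this read-out higher numbers stand for weaker inhibition and lower numbers for stronger inhibition), compound 3 gives 65800 nM; compound 1 gives 59800 nM and compound 2 gives 49900 nM, so compound 3 sits within the scatter of both neighbours and cannot be set apart from them. Compound 4 `Cn1ccc2c(Oc3ccc(NC(=O)c4cc5cccnc5n(-c5ccc(C(F)(F)F)c(Cl)c5)c4=O)cc3)ncnc21` carries a different pendant aryl group: 3-chloro-4-(trifluoromethyl)phenyl in place of 4-methoxyphenyl on an aromatic nitrogen. The measured steps that bear on this are a 1.2-fold lower number from compound 1 to compound 2 (0.08 log units; within the scatter), a 1.1-fold higher number from compound 1 to compound 3 (0.04 log units; within the scatter) and a 1.3-fold higher number from compound 2 to compound 3 (0.12 log units; within the scatter), each within the scatter, so substitution at this ring has so far left the readout essentially unchanged. For the measured compounds named here, since the new group again brings a chloro onto the same ring, the step from compound 2 to compound 3 read in reverse is the closest precedent. Compound 4 is therefore expected to show a 1.5-fold lower number from compound 3 to compound 4 (0.17 log units; within the scatter), a change within the scatter, with an estimated value of 45000 nM and a range from 18000 nM to 110000 nM.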

Compound 4, half-maximal inhibitory concentration: 289000 nM
The estimate for compound 4 lay 6.4-fold (0.81 log units) below the measured number; the measured number lies above the stated range.
By their numbers in this assay, from the lowest: compounds 2, 1 and 3 (each within the scatter of the next); then compound 4.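

In this assay the group on the aromatic nitrogen proves able to move the number after all: 3-chloro-4-(trifluoromethyl)phenyl gives a 4.4-fold higher number from compound 3 to compound 4 (0.64 log units; beyond the scatter) and a 5.8-fold higher number from compound 2 to compound 4 (0.76 log units; beyond the scatter) and a 4.8-fold higher number from compound 1 to compound 4 (0.68 log units; beyond the scatter) with all three steps beyond the scatter and towards weaker inhibition. Phenyl, 4-chlorophenyl and 4-methoxyphenyl could not be told apart at this position, so the change in compound 4 is the first here to register, and the chloro shared by compound 2 and compound 4 does not keep their numbers together. Nothing measured here accounts for the shift.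

The chloro and the trifluoromethyl enter together, so the compounds shown leave open which of them, alone or only in combination, carries the step. They also leave open how an amine or a carboxylic acid on this ring would read.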